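Ether side chains on a shared core: outlook for compound 4

The source may hold more compounds than are shown below. What is called first, only, known or untested is meant among the compounds shown, and "the series" means these compounds.

compound 1 `COCCOCCOc1cccc2ccc(N)nc12` in an assay on cells with melanin-concentrating hormone receptor 1 (Homo sapiens) as the target, read by radioligand binding; on this read-out lower numbers stand for stronger inhibition and higher numbers for weaker inhibition: > 2000 nM
compound 2 `CC#CCCOc1cccc2ccc(N)nc12`: > 2000 nM
compound 3 `CC(C)=CCOc1cccc2ccc(N)nc12`: > 2000 nM

Going by the values given here, every value so far is a limit of this assay and not a number. Compound 1 gives > 2000 nM, a limit. Compound 2 gives > 2000 nM, again a limit. Compound 3 gives > 2000 nM, once more a limit, so compound 3 stands where all measured compounds stand, with nothing to rank it against the other two. The measured steps are therefore unreadable: a step that the two limits leave unreadable from compound 1 to compound 2, a step that the two limits leave unreadable from compound 1 to compound 3 and a step that the two limits leave unreadable from compound 2 to compound 3. The whole of the evidence is the limit of > 2000 nM in this assay, at which 3 of the 3 values shown sit.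

Compound 4 `COC(C)(C)CCOc1cccc2ccc(N)nc12` differs from compound 3 by 2-methoxy-2-methylpropyl in place of 2-methylprop-1-en-1-yl on a saturated chain carbon bound to an oxygen on an aromatic ring. Among the compounds with values here, no measured step reads on this change, since the three steps among the measured compounds give neither size nor direction. The step is therefore expected to stay unreadable as well, a step that the limit leaves unreadable from compound 3 to compound 4, most likely ending at the same limit. Compound 4 is estimated at 4000 nM, expected between 1000 nM and 15000 nM.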

Compound 4, half-maximal inhibitory concentration: 132 nM
The estimate for compound 4 lay 30-fold (1.48 log units) above the measured number; the whole stated range lies above it.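

In this assay, the side chain gives the first readable result of the series, with 2-methoxy-2-methylpropyl in place of 2-methylprop-1-en-1-yl giving an at least 15-fold lower number from compound 3 to compound 4 (1.18 log units; beyond the scatter). An oxygen in the chain is not enough on its own: compound 1 also has ether oxygens in its chain, and the comparison with it gives an at least 15-fold lower number from compound 1 to compound 4 (1.18 log units; beyond the scatter), while replacing the alkyne of compound 2 gives an at least 15-fold lower number from compound 2 to compound 4 (1.18 log units; beyond the scatter). All three steps are minimum sizes, set by one shared limit: the limit of > 2000 nM in this assay, at which 3 of the 4 values shown sit.

The compounds shown do not separate the contribution of the methoxy group in compound 4 from that of the branched carbon bearing it. A hydroxy group or an amine in place of that methoxy group would bear on this question, and a longer chain would show whether the chain length tolerates change.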